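Replacing the hydroxamic acid end group on compound 1

The source may hold more compounds than are shown below. What is called first, only, known or untested is meant among the compounds shown, and "the series" means these compounds.

Measured compounds:
compound 1, `Nc1ncnc2c1c(-c1cnc3[nH]ccc3c1)nn2CCCC(=O)NO`: > 150000 nM
compound 2, `Nc1nc2cc(-c3nn(CCCCC(=O)NO)c4ncnc(N)c34)ccc2o1`: 14000 nM

Both compounds were tested in a functional assay on MCF7 cells (Homo sapiens) for inhibition, read by MTT assay, with a stated time of 72 h; a lower number here means a stronger inhibitor, a higher number a weaker inhibitor. For compound 1 the result > 150000 nM is only a limit of the assay, not a number; this is the point at which one of the two values sits (the limit of > 150000 nM in this assay, at which 1 of the 2 values shown sits). Compound 2 gives 14000 nM in this assay, a number rather than a limit. Compound 1 and compound 2 differ in more than one place, so nothing is known about which change matters between them.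

Compound 3, `CNC(=O)CCCCCCCn1nc(-c2cnc3[nH]ccc3c2)c2c(N)ncnc21`, has not yet been measured. It differs from compound 1 in one place: 4-(methylcarbamoyl)butyl in place of hydroxycarbamoyl on a saturated chain carbon, three bonds along the chain from an aromatic nitrogen. The chain becomes longer and the hydroxycarbamoyl group is gone. Going by the values given here, no measured step shows what such a change does in this assay. Since compound 1 already stands at a limit, the step from compound 1 to compound 3 is expected to be no change beyond the scatter, a number no higher from compound 1 to compound 3 (the limit leaves the size open). Compound 3 is therefore estimated at 150000 nM in this assay, with a range from 30000 nM to 600000 nM, and most likely the assay will again report only a limit.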

Compound 3, half-maximal inhibitory concentration: 7570 nM
Compound 3: middle estimate off by 20-fold (1.30 log units), on the high side; the whole stated range lies above it.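

In this assay, the hydroxycarbamoyl group proves not to be required for a measurable result on the core of compound 1: putting 4-(methylcarbamoyl)butyl in its place gives an at least 19-fold lower number from compound 1 to compound 3 (1.29 log units; beyond the scatter) as a single change at this position. On these data alone, the true size of this step stays open, since compound 1 gives only a limit of the assay and not a number: the limit of > 150000 nM in this assay, at which 1 of the 3 values shown sits. Going by these compounds alone, until now, the only compounds with a measured comparison differed in more than one place, whereas this step shows that a change on this saturated chain carbon, three bonds along the chain from an aromatic nitrogen, can by itself move the result well beyond the usual scatter.

This one step both lengthens the chain and removes the hydroxycarbamoyl group, and the compounds shown cannot separate those two parts of the change. A longer chain still ending in hydroxycarbamoyl would test the length alone, while a carboxylic acid or an unsubstituted amide at the end of the longer chain would show how much the end group itself matters.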